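The source may report more compounds than this note shows. Statements on the series, on what has been measured and on what is new or still open speak of the compounds shown alone.

Of the compounds shown here, three have been measured so far in a functional assay on the whole organism (strain Wister albino) for inhibition, with Rattus norvegicus as the target, read by paw edema, with stated times of 1 h and 2 h, at a dose of 50 mg/kg by the intraperitoneal route; on this read-out lower numbers stand for less inhibition and higher numbers for more inhibition at the one dose given (going by the name of the read-out). Compound 1 `CN1C(=O)[C@@]2(c3ccccc31)N(C)C[C@@H](c1ccc(F)cc1)[C@@]21Cc2ccccc2C1=O` gives 24.6%, compound 2 `Cc1ccc([C@@H]2CN(C)[C@]3(C(=O)N(C)c4ccccc43)[C@]23Cc2ccccc2C3=O)cc1` gives 8%, and compound 3 `CN1C(=O)[C@@]2(c3ccccc31)N(C)C[C@@H](c1cccs1)[C@@]21Cc2ccccc2C1=O` gives 10.8%. On these numbers compound 3 stands second highest of the three: its nearest neighbour is compound 2, a gap within the scatter, and its furthest is compound 1, with a number 13.8 percentage points lower from compound 1 to compound 3 (beyond the scatter), a gap beyond the scatter. The step of a number 2.8 percentage points higher from compound 2 to compound 3 (within the scatter) lies within the scatter.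

Compound 4 `COc1ccc([C@@H]2CN(C)[C@]3(C(=O)N(C)c4ccccc43)[C@]23Cc2ccccc2C3=O)cc1` is the next to be tested in this assay. It differs from compound 3 in one place: 4-methoxyphenyl in place of thiophen-2-yl on a saturated ring carbon. For the measured compounds named here, two measured steps bear on this change. The swap of the group on the saturated ring carbon, seen in a number 13.8 percentage points lower from compound 1 to compound 3 (beyond the scatter) and a number 2.8 percentage points higher from compound 2 to compound 3 (within the scatter), moved the number by a modest amount at most, and the change of a substituent on the aromatic ring, seen in a number 16.6 percentage points lower from compound 1 to compound 2 (beyond the scatter), was likewise modest. Going by the values given here, no methoxy-bearing compound has been measured, so the direction of any step is open. Given the closeness of compound 2 and compound 3, the step of a number 1.2 percentage points higher from compound 3 to compound 4 (within the scatter) is expected to stay within the scatter. Compound 4 is therefore estimated at 12%, with a range from 4% to 26%.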

Compound 4, a percentage reported as inhibition, in the whole organism at one dose (the size of the read-out at that dose, not a potency): 20.2%
Compound 4: the middle estimate sits 8.2 percentage points below what was measured; low and high end bracket the measured number.
By their numbers in this assay, from the lowest: compounds 2, 3, 4 and 1 (each within the scatter of the next, the first and the last beyond it).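

The methoxy compound shows that on the aromatic carbon of this phenyl group, the outcome in this assay does not simply follow the earlier drop seen with methyl: methoxy in place of methyl gives a number 12.2 percentage points higher from compound 2 to compound 4 (beyond the scatter), whereas methoxy in place of fluoro gives a number 4.4 percentage points lower from compound 1 to compound 4 (within the scatter). Among the three substituents at this carbon, methyl therefore stands apart, with its steps to both fluoro and methoxy beyond the scatter, while fluoro and methoxy cannot be told apart. The change from thiophen-2-yl to 4-methoxyphenyl on the saturated ring carbon gives a number 9.4 percentage points higher from compound 3 to compound 4 (within the scatter), so this exchange of a five-membered ring for a six-membered one cannot be separated from the scatter, and nothing available explains any of these differences.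

The compounds shown leave open whether a chloro or a hydroxy group on the same aromatic carbon would stay with fluoro and methoxy or fall with methyl. They also leave open how an amine or a carboxylic acid on this phenyl ring would read at this single dose.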